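Ring oxygen in the sugar-like substituent: compound 2 to compound 3

The source may hold more compounds than are shown below. What is called first, only, known or untested is meant among the compounds shown, and "the series" means these compounds.

Measured so far:
compound 1, `CCCn1c(=O)n(C2CCC(COC(C)=O)O2)c2nc(NC(C)=O)nc(O)c21`, 154 uM
compound 2, `C=CCn1c(=O)n(C2CCC(CO)C2)c2nc(N)nc(O)c21`, 226 uM

In a functional assay (B cells) with Mus musculus as the target (a higher number here means that more compound is needed for the effect, a lower number that less compound is needed), compound 2 gives 226 uM, the highest of the two numbers recorded so far. Compound 1 gives 154 uM in this assay, which sits within the scatter of compound 2, so no order between the two can be read from these values. Going by the values given here, no step between measured compounds that differ in one place has been recorded, so no measured step is available for guidance.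

Compound 3, `C=CCn1c(=O)n([C@H]2CO[C@@H](CO)C2)c2nc(N)nc(O)c21`, is the next compound to be measured in this assay. It differs from compound 2 as follows: a group of 7 heavy atoms (5 carbon, 2 oxygen; one five-membered non-aromatic ring with 1 hetero atom) in place of a group of 7 heavy atoms (6 carbon, 1 oxygen; one five-membered non-aromatic ring of carbon only), on an aromatic nitrogen. The substituent that enters carries two defined stereocentres.

Among the compounds with values here, with no measured step of this kind, the step from compound 2 to compound 3 in this assay is expected to be small, a 1.3-fold lower number from compound 2 to compound 3 (0.10 log units; within the scatter), and not beyond the scatter. Compound 3 is therefore estimated at 180 uM, with a range from 60 uM to 540 uM.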

Compound 3, concentration for half-maximal effect: 83 uM
Beside the measured number, compound 3's estimate is 2.2-fold (0.34 log units) above it, and the stated range covers the measured number.
By their numbers in this assay, from the lowest: compounds 3, 1 and 2 (each within the scatter of the next, the first and the last beyond it).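

In this assay, a five-membered non-aromatic ring with 1 hetero atom in place of the ring of carbon only, on the aromatic nitrogen, gives a 2.7-fold lower number from compound 2 to compound 3 (0.44 log units; beyond the scatter). Going by these compounds alone, this is the first measured step, and it shows that this position responds to a change within the ring itself: both groups have 7 heavy atoms, while the hydrogen-bond acceptors go from 1 to 2 and 2 defined stereocentres enter. No measurement at hand gives a reason for this step.

On these data alone, how much of the step belongs to the ring oxygen and how much to the defined stereocentres stays open, as both change together from compound 2 to compound 3. Also open, as far as these compounds go, is whether the step holds with an amine or a carboxylic acid on this ring, or with a longer chain in place of the allyl group.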